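The source may hold more compounds than are shown below. What is called first, only, known or untested is meant among the compounds shown, and "the series" means these compounds.

Compound 1 `ClCc1ccccc1Cn1cnc2c(Cl)nc(Cl)nc21` gives 1540 nM in a functional assay on RPMI-8226 cells (Homo sapiens) for cytotoxicity, read by sulforhodamine B assay, with a stated time of 48 h; on this read-out higher numbers stand for weaker inhibition of growth and lower numbers for stronger inhibition of growth. Compound 2 `ClCc1ccccc1Cn1cnc2c(Cl)ncnc21` gives 40700 nM. Compound 3 `ClCc1cccc(Cn2cnc3ncnc(Cl)c32)c1` gives 34700 nM.

Compound 2 and compound 1 share a core and differ in one place, (chloro in place of hydrogen on an aromatic carbon); that change gave a 26-fold lower number from compound 2 to compound 1 (1.42 log units; beyond the scatter). Compound 3 and compound 2 have the same atoms joined differently, and the difference between the two cores is not broken down here; their two numbers lie within the usual scatter of each other.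

Compound 4 `ClCc1cccc(Cn2cnc3nc(Cl)nc(Cl)c32)c1` has not yet been measured. Going by the values given here, it differs from compound 3 by chloro in place of hydrogen on an aromatic carbon, the same change, at the same kind of place, as the one from compound 2 to compound 1. The expectation for it rests on compound 3 giving 34700 nM and on the step of a 26-fold lower number from compound 2 to compound 1 (1.42 log units; beyond the scatter). Compound 4 is expected to show a step of a 25-fold lower number from compound 3 to compound 4 (1.39 log units; beyond the scatter). Compound 4 is estimated at 1400 nM, with a likely range from 500 nM to 4000 nM.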

Compound 4, concentration for total growth inhibition: 4160 nM
Beside the measured number, compound 4's estimate is 3.0-fold (0.47 log units) below it; the whole stated range lies below it.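

Putting the chloro group on the aromatic carbon between two ring nitrogen atoms again lowers the number in this assay with an 8.3-fold lower number from compound 3 to compound 4 (0.92 log units; beyond the scatter), so the direction of the change carries over from one core to the other. Its size does not carry over unchanged, as the two steps differ by more than the scatter: the same change on two cores in this assay, a 26-fold lower number (1.42 log units; beyond the scatter) from compound 2 to compound 1 and an 8.3-fold lower number (0.92 log units; beyond the scatter) from compound 3 to compound 4, 3.2-fold (0.50 log units) apart, beyond the scatter of two such steps. Going by these compounds alone, with only two pairs, this shows that the size of the step depends on the core, but it does not show why, or what the step would be on a further core.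

The compounds shown leave open what other groups would do at that same carbon, such as an amine or a methoxy group. They also leave open whether bromo would give a step like that of chloro.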